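Dropping a Methyl Group Where Every Measured Value Is a Limit

The source may hold more compounds than are shown below. What is called first, only, known or untested is meant among the compounds shown, and "the series" means these compounds.

compound 1 `Cc1ccc2oc(CSc3nnc(N)s3)cc(=O)c2c1` — > 25000 nM
compound 2 `O=c1cc(CSc2nc3ccccc3o2)c2ccc(O)c(O)c2o1` — > 25000 nM
compound 3 `Cc1ccc2oc(CSc3nnc(C)o3)cc(=O)c2c1` — > 25000 nM

Of the compounds shown here, three have been tested in a functional assay on MCF7 cells (Homo sapiens) for cytotoxicity, read by MTT assay, with a stated time of 72 h; a lower number here means a stronger inhibitor, a higher number a weaker inhibitor. In this assay compound 1 gives > 25000 nM, which is a limit of the assay and not a number. Compound 2 likewise reaches only the limit > 25000 nM. Compound 3 also sits at the limit > 25000 nM. Compound 1 therefore stands nowhere in particular on the numbers shown: all three values are limits, and the only step between two compounds that differ in one place, a step that the two limits leave unreadable from compound 1 to compound 3, cannot be read because the limit of > 25000 nM in this assay, at which 3 of the 3 values shown sit, holds for both of its ends.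

Compound 4 `Nc1nnc(SCc2cc(=O)c3ccccc3o2)s1` has not yet been measured. It differs from compound 1 by hydrogen in place of methyl on an aromatic carbon. Within the data shown here, no measured step touches this change, and none of the measured steps gives a readable size. What is expected for the step that the limit leaves unreadable from compound 1 to compound 4 is therefore only that it should not carry compound 4 into the measurable range. The estimate for compound 4 in this assay is 30000 nM, with a range from 12000 nM to 80000 nM, most likely reported again as a limit.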

Compound 4, half-maximal inhibitory concentration: > 25000 nM
Compound 4: a limit, no number; the forecaster's own chance of this, stated with the estimate: 85%; the middle value does not contradict the limit.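

No new step can be read between compound 1 and compound 4, because both ends are limits and not numbers: the limit of > 25000 nM in this assay, at which 4 of the 4 values shown sit.

The compounds shown leave open how hydrogen in place of methyl, or any other change among them, would shift a measurable value in this assay.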